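The compounds below may be only part of what the source reports. "The series", "measured", "known", "first", "only" and "open" are said of these compounds alone.

Measured compounds:
- compound 1 `O=[N+]([O-])c1cn2c(n1)OC(COc1ccc(-c3ccc(F)cc3F)cn1)CC2`: > 64000 nM, a limit of the assay
- compound 2 `CC1(COc2cccc(-c3ccc(F)cc3)n2)CCn2cc([N+](=O)[O-])nc2O1`: > 64000 nM, a limit of the assay
- compound 3 `CC1(COc2ccc(-c3ccc(F)nc3F)cn2)CCn2cc([N+](=O)[O-])nc2O1`: > 64000 nM, a limit of the assay

In an ADME assay on MRC5 cells (Homo sapiens) for cytotoxicity, read by resazurin assay, with a stated time of 72 h (on this read-out higher numbers stand for weaker inhibition and lower numbers for stronger inhibition), compound 1 gives > 64000 nM, which is a limit of the assay and not a number. Compound 2 likewise gives > 64000 nM, again only a limit. Compound 3 gives > 64000 nM, also a limit. For the measured compounds named here, all three values sit at the same point, (the limit of > 64000 nM in this assay, at which 3 of the 3 values shown sit), so compound 3 cannot be placed above or below the other two; it stands with them at the limit, and no compound can be called more or less toxic than another.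

Compound 4 `O=[N+]([O-])c1cn2c(n1)OC(COc1ccc(-c3ccc(F)nc3F)cn1)CC2` is the next compound. It differs from compound 3 in one place: hydrogen in place of methyl on a saturated ring carbon. Going by the values given here, no step between two measured compounds is known. Given that every measured value in this assay is a limit, no movement beyond the scatter is expected for this change. Compound 4 is therefore expected to give 90000 nM, within 35000 nM to 300000 nM. The expected step that the limit leaves unreadable from compound 3 to compound 4 is estimated to be none beyond the scatter.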

Compound 4, half-maximal inhibitory concentration: > 64000 nM
Compound 4 was reported as a limit (the forecaster's own chance of this, stated with the estimate: 85%); the middle value does not contradict the limit.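

Neither the pair compound 3 and compound 4 nor the pair compound 1 and compound 4 yields a readable step in this assay, as all values are limits: the limit of > 64000 nM in this assay, at which 4 of the 4 values shown sit.

On these data alone, whether hydrogen in place of methyl, or 2,6-difluoropyridin-3-yl in place of 2,4-difluorophenyl, changes the read-out at all stays open.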